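The compounds below may be only part of what the source reports. "The series", "measured", "known", "first", "only" and "open" are said of these compounds alone.

Measured so far in a functional assay on SV5A8 cells (Homo sapiens) for cytotoxicity; a lower number here means a stronger inhibitor, a higher number a weaker inhibitor:

- Compound 1 `Cc1ccc2c(NCc3ccc(NC(=O)C4CCN(Cc5ccc(F)cc5)CC4)cc3)nc(N(C)C)nc2c1` gives > 4820 nM, which is a limit of the assay rather than a number.
- Compound 2 `CCN1CCN(c2nc(NCc3ccc(NC(=O)C4CCN(Cc5ccccc5)CC4)cc3)c3ccc(C)cc3n2)CC1` gives > 13000 nM, again a limit of the assay.
- Compound 3 `Cc1ccc2c(NCc3ccc(NC(=O)C4CCN(Cc5ccccc5)CC4)cc3)nc(N3CCCCCC3)nc2c1` gives > 6880 nM, also a limit of the assay.

Compound 1 therefore stands nowhere definite in this assay: only a limit is known for it, and the same holds for the two other compounds, as the lines (the limit of > 4820 nM in this assay, at which 1 of the 3 values shown sits), the limit of > 13000 nM in this assay, at which 1 of the 3 values shown sits, and the limit of > 6880 nM in this assay, at which 1 of the 3 values shown sits, show. For the measured compounds named here, the one measured step, a step that the two limits leave unreadable from compound 2 to compound 3, cannot be read for size or direction.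

Compound 4 `Cc1ccc2c(NCc3ccc(NC(=O)C4CCN(CC5CCNCC5)CC4)cc3)nc(N(C)C)nc2c1` is the next compound in this series. It differs from compound 1 by piperidin-4-yl in place of 4-fluorophenyl on a saturated chain carbon bound to an amine nitrogen in a ring. Going by the values given here, no measured step touches this part of the molecule, and none of the three measured values is a number, so there is no basis for expecting a shift beyond the scatter in either direction. Compound 4 is therefore expected to stay where compound 1 stands, with a step that the limit leaves unreadable from compound 1 to compound 4, most likely ending as a limit again. The estimate for compound 4 in this assay is 15000 nM, with a range from 3000 nM to 60000 nM.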

Compound 4, half-maximal inhibitory concentration: > 8070 nM
Compound 4: only a limit was reported; the forecaster's own chance of this, stated with the estimate: 80%; the middle value is on the limit's open side.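

Compound 4, like compound 1, gives only a limit of the assay in this assay, so the change from 4-fluorophenyl to piperidin-4-yl cannot be read for size or direction. The compounds shown leave open the actual value of each one, and whether any change in them moves it at all.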